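Changing the chain-end ring of compound 1

This account rests on a few compounds, and the source may have more. Where it says the series, first, only, none or still open, it means among the compounds named here.

Values measured in a functional assay on KB cells (Homo sapiens) for antiproliferative activity, read by MTT assay, with a stated time of 48 h (on this read-out lower numbers stand for stronger inhibition and higher numbers for weaker inhibition), are as follows.
Compound 1 `Cn1cc(C2=C(c3nn(CCCn4cncn4)c4ncccc34)C(=O)NC2=O)c2ccccc21` gives > 100000 nM (a limit)
Compound 2 `Cn1cc(C2=C(c3nn(CCCN4CCCCC4)c4ncccc34)C(=O)N(c3ccc(Cl)cc3)C2=O)c2ccccc21` gives > 100000 nM (a limit)
Compound 3 `Cn1cc(C2=C(c3nn(CCCN4CCCCC4)c4ncccc34)C(=O)N(c3cccc4ccccc34)C2=O)c2ccccc21` gives 13400 nM (a number)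

Compound 1 gives no number, only the limit of > 100000 nM in this assay, at which 2 of the 3 values shown sit, as its reading. Compound 4 `Cn1cc(C2=C(c3nn(CCCCn4ccnc4)c4ncccc34)C(=O)NC2=O)c2ccccc21` has not yet been measured. It has (1H-imidazol-1-yl)methyl in place of 1H-1,2,4-triazol-1-yl on a saturated chain carbon, three bonds along the chain from an aromatic nitrogen. Counted, the change reads (1H-imidazol-1-yl)methyl in place of 1H-1,2,4-triazol-1-yl on a saturated chain carbon, three bonds along the chain from an aromatic nitrogen and amounts to 3-(1H-1,2,4-triazol-1-yl)propyl giving way to 4-(1H-imidazol-1-yl)butyl.

Among the measured compounds shown here, the only measured step, an at least 7.4-fold lower number from compound 2 to compound 3 (0.87 log units; beyond the scatter), lies elsewhere, on an amide-type nitrogen in a ring, so no measured step touches this chain. In this assay only a modest move toward a lower number is expected, perhaps none that can be seen, since the starting point is a limit. The estimated step is an at least 1.4-fold lower number from compound 1 to compound 4 (0.15 log units; that floor lies within the scatter) for this change. For compound 4 the estimated value is 70000 nM within an expected range of 15000 nM to 150000 nM overall.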

Compound 4, half-maximal inhibitory concentration: > 100000 nM
Compound 4: only a limit was reported; the forecaster's own chance of this, stated with the estimate: 55%; middle value at least 1.4-fold (0.15 log units) from the limit.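

Compound 1 and compound 4 both give only a limit in this assay, so no step between them can be read: the limit of > 100000 nM in this assay, at which 3 of the 4 values shown sit.

The compounds shown leave open whether 3-(1H-1,2,4-triazol-1-yl)propyl and 4-(1H-imidazol-1-yl)butyl differ at all in this assay.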